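The compounds below may be only part of what the source reports. "The series", "measured", "known", "first", "only" and "open" are said of these compounds alone.

Measured so far in a functional assay on SV5A8 cells (Homo sapiens) for cytotoxicity; on this read-out higher numbers stand for weaker inhibition and lower numbers for stronger inhibition:
- Compound 1 `CCCCN1CCC(C(=O)Nc2ccc(CNc3nc(N(C)C)nc4cc(C)ccc34)cc2)CC1` gives > 10500 nM, a limit of this assay.
- Compound 2 `Cc1ccc2c(NCc3ccc(NC(=O)C4CCN(C(=O)OC(C)(C)C)CC4)cc3)nc(N(C)C)nc2c1` gives > 4820 nM, also a limit of this assay.

Compound 2 thus stands at a limit in this assay, as the limit of > 4820 nM in this assay, at which 1 of the 2 values shown sits, records; compound 1 sits at the other limit, (the limit of > 10500 nM in this assay, at which 1 of the 2 values shown sits). Within the data shown here, the only measured step, a step that the two limits leave unreadable from compound 1 to compound 2, is unreadable, since both ends are limits.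

Compound 3 `Cc1ccc2c(NCc3ccc(NC(=O)C4CCN(Cc5ccc(F)cc5Cl)CC4)cc3)nc(N(C)C)nc2c1` differs from compound 2 by 2-chloro-4-fluorobenzyl in place of tert-butoxycarbonyl on an amine nitrogen in a ring. Among the measured compounds shown here, the one measured step touches the same amine nitrogen in the ring and gave no readable size, so nothing measured sets a direction for this change. Only weak inhibition has been seen at this position, whether a butyl or a tert-butoxycarbonyl sits there.

For compound 3 an estimate of 8000 nM is expected, with a range from 2000 nM to 30000 nM. The expected step that the limit leaves unreadable from compound 2 to compound 3 is therefore not beyond the scatter, and another limit is the likelier outcome.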

Compound 3, half-maximal inhibitory concentration: > 5910 nM
Compound 3: no number, only a limit; the forecaster's own chance of this, stated with the estimate: 60%; the middle value lies beyond the limit too.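

Among these compounds, compound 1, compound 2 and compound 3 all stand at limits in this assay, so no step among them can be read. The compounds shown leave open whether any group on the amine nitrogen in the ring gives a numerical value in this assay.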